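The compounds below may be only part of what the source reports. "The series", "measured", "known", "first", "only" and "open" are said of these compounds alone.

Measured so far:
compound 1 `CCCCCCCCCCCCCCCCc1c(C)c(N(C)C)nc(C)c1O`, 56%
compound 2 `CCCCCCCCCCc1nc(N(C)C)c(C)c(C)c1O`, 77%

Both numbers come from a functional assay on cells (Lymphocyte, Homo sapiens), read by trypan blue exclusion, with a stated time of 16 h, tested at 0.5 uM; a higher number here means a stronger effect of the compound at the concentration tested, a lower number a weaker effect. Compound 2 holds the higher of the two, and compound 1 sits a gap below it that lies beyond the usual scatter. The two structures differ in several places at once, so no single step can be read between them; the gap says only what the two values show.

Compound 3 `CCCCCCCCCCCCCCCCc1nc(N(C)C)c(C)c(C)c1O` is not yet measured. It differs from compound 2 in one place: hexyl in place of hydrogen on a saturated chain carbon, ten or more bonds along the chain from an aromatic carbon. The expectation is a modest fall in this assay from compound 2 to compound 3, possibly no larger than the scatter. The expected step is a number 11 percentage points lower from compound 2 to compound 3 (beyond the scatter). Compound 1, which also carries the longer chain, gives 56% and stays below compound 2. Compound 3 is estimated at 66%, within 45% to 84%.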

Compound 3, a percentage reported as activity, at one concentration (the size of the read-out at that concentration, not a potency): 78%
Compound 3: middle estimate off by 12 percentage points, on the low side, within the range that was stated.
By their numbers in this assay, from the lowest: compound 1; then compounds 2 and 3 (each within the scatter of the next).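

In this assay, hexyl in place of hydrogen on a saturated chain carbon, ten or more bonds along the chain from an aromatic carbon, gives a number 1 percentage points higher from compound 2 to compound 3 (within the scatter). Among the compounds shown here, this is the first one-place step, and it shows that compound 2 and compound 3 cannot be told apart at this position despite the six added carbon atoms, at least at the one concentration tested. No supporting measurement bears on this result, so it stands as an observation only.

As far as these compounds go, whether a shorter chain, a longer chain, or a chain carrying a carboxylic acid or an amine would read alike at this position remains open. Also open, from the compounds shown here alone, is whether compound 2 and compound 3 would still read alike at other concentrations, since a single-concentration read-out is not a potency.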